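Propyl to phenyl: a step with little precedent

A few compounds are considered here, and "the series" means these few. Any claim that something is new, unique, unknown or untested is made for them only; others in the source may bear on it.

Compound 1 `O=C(Nc1ccc(Nc2nccc(NC3CC3)n2)cc1)Nc1ccc(Cl)c(C(F)(F)F)c1`: 18500 nM
Compound 2 `CCCNc1ccnc(Nc2ccc(NC(=O)Nc3ccc(Cl)c(C(F)(F)F)c3)cc2)n1`: 7320 nM

In a functional assay on A549 cells (Homo sapiens) for antiproliferative activity, read by MTT assay, with a stated time of 72 h (on this read-out lower numbers stand for stronger inhibition and higher numbers for weaker inhibition), compound 2 gives 7320 nM, the lower of the two numbers, and so the stronger inhibition of this pair. The next structure, compound 3 `O=C(Nc1ccc(Nc2nccc(Nc3ccccc3)n2)cc1)Nc1ccc(Cl)c(C(F)(F)F)c1`, carries phenyl in place of propyl on a nitrogen on an aromatic ring. Among the measured compounds shown here, only one measured step bears on this change: a 2.5-fold lower number from compound 1 to compound 2 (0.40 log units; beyond the scatter), a modest move made by putting propyl in place of cyclopropyl at that nitrogen. Neither group in that step is phenyl, so it offers only weak guidance and points to no firm direction. The expected result is a 1.0-fold lower number from compound 2 to compound 3 (0.02 log units; within the scatter), which would mean no clear shift beyond the scatter in this assay. For compound 3 the estimated value is 7000 nM, with an expected range of 2500 nM to 20000 nM.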

Compound 3, half-maximal inhibitory concentration: > 50000 nM
Compound 3 was reported as a limit; the forecaster's own chance of this, stated with the estimate: 5%; middle value at least 7.1-fold (0.85 log units) from the limit.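

In this assay, compound 3 is reported only as a limit of the assay, not as a number: the limit of > 50000 nM in this assay, at which 1 of the 3 values shown sits. Propyl and cyclopropyl had so far shown only a modest difference at this nitrogen, whereas phenyl gives an at least 6.8-fold higher number from compound 2 to compound 3 (0.83 log units; beyond the scatter) and an at least 2.7-fold higher number from compound 1 to compound 3 (0.43 log units; beyond the scatter), both steps towards weaker inhibition. Among these compounds, then, the group on this nitrogen can shift the result well beyond the scatter, and the anilino compound, the only one with an aromatic ring at this place, is weaker than both compounds that carry a non-aromatic group there.

On these data alone, how much weaker compound 3 really is remains unknown. The compounds shown also leave open whether the loss comes with any ring at this nitrogen, as a benzyl or cyclohexyl group would test, or whether a longer chain such as butyl would also lose activity.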